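This account rests on a few compounds, and the source may have more. Where it says the series, first, only, none or still open, it means among the compounds named here.

Working notes on the series. All compounds share one core and the same side chain. Compound 1 `O=C(NCCCCc1ccccc1)n1c(-c2ccccc2)coc1=O` gives 70 nM in an assay on isolated protein for inhibition of acid ceramidase (Homo sapiens), read by LC-MS, with a stated time of 1 h; a lower number here means a stronger inhibitor, a higher number a weaker inhibitor. For the measured compounds named here, compound 2 `O=C(NCCCCc1ccccc1)n1c(-c2ccc(Cl)cc2)coc1=O` gives 5 nM in this assay; the only one-place step measured so far, a 14-fold lower number from compound 1 to compound 2 (1.15 log units; beyond the scatter), is a large one. Compound 3 `O=C(NCCCCc1ccccc1)n1cc(-c2ccc(F)cc2)oc1=O` gives 185 nM in this assay and stands at the highest number of the three: the nearest is compound 1, whose number is lower by a margin beyond the scatter, and the furthest is compound 2, whose number is lower by a much wider margin, also beyond the scatter.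

Compound 4 `CN1CCC(c2cn(C(=O)NCCCCc3ccccc3)c(=O)o2)CC1` has not yet been measured. It differs from compound 3 in one place: 1-methylpiperidin-4-yl in place of 4-fluorophenyl on an aromatic carbon. Going by the values given here, no measured step bears directly on this change. Among the compounds with values here, the single step in hand, a 14-fold lower number from compound 1 to compound 2 (1.15 log units; beyond the scatter), concerns chloro in place of hydrogen on an aromatic carbon and gives no guide to exchanging an aromatic ring for a non-aromatic one. Without precedent, the expectation for compound 4 in this assay is a step of a 1.9-fold higher number from compound 3 to compound 4 (0.28 log units; within the scatter), with the direction uncertain. The estimate for compound 4 in this assay is therefore 350 nM, expected between 90 nM and 1500 nM.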

Compound 4, half-maximal inhibitory concentration: 1400 nM
Compound 4: the middle estimate sits 4.0-fold (0.60 log units) below what was measured, within the range that was stated.
By their numbers in this assay, from the lowest: compound 2; then compound 1; then compound 3; then compound 4.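

For the compounds shown here, the change at the aromatic carbon next to the ring oxygen gives a 7.6-fold higher number from compound 3 to compound 4 (0.88 log units; beyond the scatter) in this assay, the only one-place step at this position so far. It shows that this position responds to the exchange of 4-fluorophenyl for 1-methylpiperidin-4-yl, although compound 4 still gives a measured 1400 nM. The two groups have the same count of heavy atoms and each holds one six-membered ring, but they differ in aromaticity, in the ring nitrogen and in the hydrogen-bond acceptor that enters, and no measurement at hand explains the loss.

This single pair leaves open which of those differences carries the step: cyclohexyl at this position would test a non-aromatic ring of carbon only, while piperidin-4-yl without the methyl would test the methyl on the ring nitrogen. It also leaves open whether the step from hydrogen to chloro, a 14-fold lower number from compound 1 to compound 2 (1.15 log units; beyond the scatter), carries over to this position, a question that 4-chlorophenyl here would address against the 4-fluorophenyl of compound 3.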